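A few compounds are considered here, and "the series" means these few. Any claim that something is new, unique, unknown or untested is made for them only; others in the source may bear on it.

Measured in an ADME assay on liver for metabolic stability, with Liver microsome (Homo sapiens) as the target, using microsomes; a lower number here means slower removal, a higher number faster removal of the compound:
- compound 1 `CC(=O)Nc1cccc(Nc2cc(NC3CC3)n3ncc(C#N)c3n2)c1`: 20 mL.min-1.g-1
- compound 2 `CC(=O)Nc1cc(Nc2cc(NC3CC3)n3ncc(C#N)c3n2)ccc1N1CCC[C@@H](N(C)C)C1`: 19 mL.min-1.g-1

For the measured compounds named here, compound 2 stands level with the only other measured compound, since the two values lie within the scatter of each other. Compound 3 `CC(=O)Nc1cc(Nc2cc(NC3CC3)n3ncc(C#N)c3n2)ccc1N1CC[C@@H](N)C1` keeps the shared core and alters one group: a group of 6 heavy atoms (4 carbon, 2 nitrogen; one five-membered non-aromatic ring with 1 hetero atom) in place of a group of 9 heavy atoms (7 carbon, 2 nitrogen; one six-membered non-aromatic ring with 1 hetero atom), on an aromatic carbon. The group that enters is 3-aminopyrrolidin-1-yl, on an aromatic carbon ortho to an acetamido group.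

Going by the values given here, one measured step bears on this change, and it involves the same kind of group. It is a 1.1-fold lower number from compound 1 to compound 2 (0.02 log units; within the scatter), which lies within the scatter even though a group of 9 heavy atoms replaced a hydrogen atom. Among the compounds with values here, a single step is thin evidence, and no measured compound yet carries a five-membered ring at this place. Still, that step gives no reason to expect a swap for a smaller group to move this assay far, so no shift beyond the scatter is expected. The expected change is small: a 1.2-fold lower number from compound 2 to compound 3 (0.07 log units; within the scatter). For compound 3 the estimate is 16 mL.min-1.g-1, with an expected range of 9 mL.min-1.g-1 to 28 mL.min-1.g-1.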

Compound 3, intrinsic clearance in microsomes: < 3 mL.min-1.g-1
Compound 3 gave a limit, no number (the forecaster's own chance of this, stated with the estimate: 3%); at least 5.3-fold (0.72 log units) between middle value and limit.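

Compound 1 and compound 2 suggested that this place on the aromatic ring had little bearing on this assay, as adding a large group there stayed within the scatter: a 1.1-fold lower number from compound 1 to compound 2 (0.02 log units; within the scatter). The new result shows that the place is not indifferent and that the identity of the group counts, not merely the presence of one: putting 3-aminopyrrolidin-1-yl on the aromatic carbon ortho to an acetamido group in place of the larger group gives an at least 6.3-fold lower number from compound 2 to compound 3 (0.80 log units; beyond the scatter), and setting the same group against plain hydrogen gives an at least 6.6-fold lower number from compound 1 to compound 3 (0.82 log units; beyond the scatter). Compound 3 stands at a limit of the assay and not at a number, so both of these steps give only a smallest size: the limit of < 3 mL.min-1.g-1 in this assay, at which 1 of the 3 values shown sits.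

Compound 3 differs from compound 2 in both ring size and the amine it carries, so the compounds shown leave open whether the five-membered ring, the unsubstituted amine or the two together go with the lower number. A 3-aminopiperidin-1-yl group would pair the six-membered ring with the unsubstituted amine, and a 3-(dimethylamino)pyrrolidin-1-yl group would pair the five-membered ring with the dimethylamino group, which would pull these two changes apart.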